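The compounds below may be only part of what the source reports. "The series", "measured", "known", "first", "only" and "open" are said of these compounds alone.

In an assay on isolated protein (strain Sprague-Dawley) for inhibition of Amine oxidase [flavin-containing] B (Rattus norvegicus), read by spectrophotometry, with a stated time of 5 min (a lower number here means a stronger inhibitor, a higher number a weaker inhibitor), the three measured compounds stand as follows:
compound 1 `Nc1cc(=O)oc2cc(OCc3cccc(Cl)c3)ccc12`: 47.9 nM
compound 2 `CCOC(=O)Nc1cc(=O)oc2cc(OCc3cccc(Cl)c3)ccc12`: 589 nM
compound 3 `CCNc1cc(=O)oc2cc(OCc3cccc(Cl)c3)ccc12`: 28.2 nM

Compound 3 shows the lowest number of the three, although the gap to compound 1 lies within the scatter, while the step of a 21-fold lower number from compound 2 to compound 3 (1.32 log units; beyond the scatter) lies well beyond it. Compound 4 `N#Cc1cc(=O)oc2cc(OCc3cccc(Cl)c3)ccc12` differs from compound 3 in one place: cyano in place of ethylamino on an aromatic carbon. Going by the values given here, no measured step swaps a nitrogen-bearing group for a cyano group, so the guidance is indirect. The step of a 1.7-fold lower number from compound 1 to compound 3 (0.23 log units; within the scatter) left the number within the scatter, whereas a 12-fold higher number from compound 1 to compound 2 (1.09 log units; beyond the scatter) was large. A change as drastic as losing the donor is therefore expected to move the number upward by a moderate step, a 3.9-fold higher number from compound 3 to compound 4 (0.59 log units; beyond the scatter), and compound 4 is estimated at 110 nM, with a range from 15 nM to 800 nM.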

Compound 4, half-maximal inhibitory concentration: 102 nM
Compound 4: middle estimate off by 1.1-fold (0.03 log units), on the high side, and the stated range covers the measured number.
By their numbers in this assay, from the lowest: compounds 3 and 1 (each within the scatter of the next); then compound 4; then compound 2.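

Replacing the nitrogen-linked groups with cyano, which has no hydrogen-bond donor, keeps the number in the same general range at this position: the step is a 3.6-fold higher number from compound 3 to compound 4 (0.56 log units; beyond the scatter), and a 2.1-fold higher number from compound 1 to compound 4 (0.33 log units; beyond the scatter), both only modest. The same group still does better than the (ethoxycarbonyl)amino group, with a 5.8-fold lower number from compound 2 to compound 4 (0.76 log units; beyond the scatter). No measurement here explains these steps.

As far as these compounds go, it remains open how a dimethylamino group, a carboxylic acid or a longer chain on the nitrogen would compare. The compounds shown also cannot separate the missing donor from the other differences between these groups.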